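Meta amino for fluoro on compound 1's aryl ring

The compounds below may be only part of what the source reports. "The series", "measured", "known", "first", "only" and "open" are said of these compounds alone.

Compound 1 `Cn1c(=O)c2nc(-c3cccc(F)c3)[nH]c2n(C)c1=O` is the reference here. In an assay for binding affinity to adenosine receptor A1 (Bos taurus) (a lower number here means a stronger inhibitor, a higher number a weaker inhibitor), compound 1 gives 4 nM, the lowest number of the three measured compounds; its steps to compound 3 and compound 2 both lie beyond the scatter. Compound 3 `CCn1c(=O)c2nc(-c3ccc(S(=O)(=O)N4CCOCC4)cc3)[nH]c2n(CC)c1=O` gives 13 nM in this assay, and compound 2 `Cc1cc(O)cc(C)c1-c1nc2c(=O)n(C)c(=O)n(C)c2[nH]1` gives 30 nM. Compound 4 `Cn1c(=O)c2nc(-c3cccc(N)c3)[nH]c2n(C)c1=O` has not been measured in this assay. It differs from compound 1 by amino in place of fluoro on an aromatic carbon. Among the measured compounds shown here, no measured pair shows this change, so no step size is known from the data. The change is expected to cost little or nothing beyond the scatter, giving an estimated step of a 2.0-fold higher number from compound 1 to compound 4 (0.30 log units; within the scatter). For compound 4 the expected value in this assay is 8 nM, within a range from 2 nM to 40 nM.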

Compound 4, half-maximal inhibitory concentration: 10 nM
The estimate for compound 4 lay 1.3-fold (0.10 log units) below the measured number, within the range that was stated.
By their numbers in this assay, from the lowest: compound 1; then compounds 4 and 3 (each within the scatter of the next); then compound 2.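

Amino in place of fluoro gives the first measured step at this position in this assay (a 2.5-fold higher number from compound 1 to compound 4 (0.40 log units; beyond the scatter)), modest but beyond the scatter. The position therefore responds to this exchange, with fluoro giving the lower number, while the amino compound keeps a nanomolar value. Nothing available explains the rise in the number.

Going by these compounds, whether the step reflects the arrival of amino or the departure of fluoro remains open. Chloro, hydroxyl or methoxy on the same aromatic carbon would help separate the two.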